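Sulfamoyl series: removing N-methyls on the sulfonamide

A few compounds are considered here, and "the series" means these few. Any claim that something is new, unique, unknown or untested is made for them only; others in the source may bear on it.

Compound 2 `CCN1CCCC1CNC(=O)c1cc(N(C)S(=O)(=O)N(C)C)ccc1OC` gives 1 mg/kg in a functional assay on the whole organism for inhibition, with Canis familiaris (Canis lupus familiaris) as the target (on this read-out higher numbers stand for an effect only at larger amounts of compound and lower numbers for an effect already at smaller amounts), and it stands level with compound 1 `CCN1CCCC1CNC(=O)c1cc(NS(=O)(=O)N(C)C)ccc1OC` at 1 mg/kg and compound 3 `CCN1CCCC1CNC(=O)c1cc(N(C)S(=O)(=O)N(C)C)c(C)cc1OC` at 1 mg/kg. The step of no change at the digits printed from compound 1 to compound 2 (within the scatter) and the step of no change at the digits printed from compound 2 to compound 3 (within the scatter) both stayed within the scatter. Compound 4 `CCN1CCCC1CNC(=O)c1cc(NS(N)(=O)=O)ccc1OC` carries the change (sulfamoylamino in place of (dimethylsulfamoyl)(methyl)amino on an aromatic carbon). Within the data shown here, the step from compound 1 to compound 2 bears on it, since that step also touched the sulfonamide nitrogen and showed nothing beyond the scatter; no measured step removes the two methyls on the other sulfonamide nitrogen, so that part is uncovered. Compound 4 is therefore expected to stay near compound 2, with an expected step of no change at the digits printed from compound 2 to compound 4 (within the scatter). The estimate for compound 4 in this assay is 1 mg/kg, ranging from 0.4 mg/kg to 3 mg/kg.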

Compound 4, dose for half-maximal effect: 10 mg/kg
Beside the measured number, compound 4's estimate is 10-fold (1.00 log units) below it; measured number above the stated range.
By their numbers in this assay, from the lowest: compounds 1, 2 and 3 (each within the scatter of the next); then compound 4.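

In this assay, amino in place of dimethylamino on the sulfonyl sulfur gives a 10-fold higher number from compound 1 to compound 4 (1.00 log units; beyond the scatter), whereas methyl in place of hydrogen on the sulfonamide nitrogen gave no change at the digits printed from compound 1 to compound 2 (within the scatter), so the two nitrogens of this group do not behave alike. Among these compounds, the full replacement by sulfamoylamino gives a 10-fold higher number from compound 2 to compound 4 (1.00 log units; beyond the scatter), a step of the same printed size as the single change at the sulfonyl sulfur. Nothing at hand gives a reason for these steps. Open, from the compounds shown here alone, is whether a methylamino group on the sulfonyl sulfur stays level with compound 1 or follows compound 4. Also open, going by these compounds, is how a diethylamino group there would read.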